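The compounds below may be only part of what the source reports. "The series", "measured", "known", "first", "only" and "open" are said of these compounds alone.

Three compounds have been measured in an assay on isolated protein for inhibition of retinal dehydrogenase 2 (Homo sapiens); on this read-out lower numbers stand for stronger inhibition and higher numbers for weaker inhibition:

Compound 1 `CC(Sc1nc2c(cnn2C)c(=O)n1-c1ccccc1)c1cccc(F)c1` gives 110 nM.
Compound 2 `C#Cc1ccc(-n2c(SC(C)c3ccccc3)nc3c(cnn3C)c2=O)cc1` gives 800 nM.
Compound 3 `CCC(Sc1nc2c(cnn2C)c(=O)n1-c1ccccc1)c1ccccc1` gives 179 nM.

Compound 3 stands second highest of these three numbers. Its nearest neighbour is compound 1, reached by a 1.6-fold higher number from compound 1 to compound 3 (0.21 log units; within the scatter); compound 2 lies furthest from it, with the values of compound 2 and compound 3 differing beyond the scatter.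

Compound 4 `CC(Sc1nc2c(cnn2C)c(=O)n1-c1ccccc1)c1ccccc1` is the next step from compound 3: hydrogen in place of methyl on a saturated chain carbon, two bonds along the chain from an aromatic carbon and a sulfur. For the measured compounds named here, the only measured step touching this chain is a 1.6-fold higher number from compound 1 to compound 3 (0.21 log units; within the scatter), which also carried a fluorine change and stayed within the scatter. No step beyond the scatter is therefore expected, and compound 4 is estimated to come in with a 1.3-fold lower number from compound 3 to compound 4 (0.11 log units; within the scatter), at 140 nM, most likely between 60 nM and 350 nM.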

Compound 4, half-maximal inhibitory concentration: 110 nM
The estimate for compound 4 lay 1.3-fold (0.10 log units) above the measured number; the measured number falls inside the stated range.
By their numbers in this assay, from the lowest: compounds 1, 4 and 3 (each within the scatter of the next); then compound 2.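

In this assay, the chain change now stands alone, ethyl to methyl, giving a 1.6-fold lower number from compound 3 to compound 4 (0.21 log units; within the scatter), and hydrogen in place of fluoro on an aromatic carbon gives no change at the digits printed from compound 1 to compound 4 (within the scatter), so each part of the earlier mixed step stays within the scatter. Hydrogen in place of ethynyl on an aromatic carbon, by contrast, gives a 7.3-fold lower number from compound 2 to compound 4 (0.86 log units; beyond the scatter), the only one of these steps beyond the scatter. No measurement here explains these results. Still open, on these data alone, is whether a longer chain on the saturated chain carbon, or an amine on an aromatic carbon, would shift the number beyond the scatter.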